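The source may report more compounds than this note shows. Statements on the series, on what has been measured and on what is new or still open speak of the compounds shown alone.

Measured so far:
- compound 1, `CC(C)Cc1ccc2c(NCCCNCc3ccco3)ccnc2c1`: 16000 nM
- compound 2, `COc1cccc(Oc2ccc3c(NCCCNCc4cc(F)ccc4OC)ccnc3c2)c1`: 7100 nM
- compound 3, `COc1cccc(CNCCCNc2ccnc3cc(CCC(C)C)ccc23)c1O`: 5390 nM

All three compounds share one core and have been tested in an ADME assay on HepG2 cells (Homo sapiens) for cytotoxicity, read by luminescence, CellTiter-Glo and ATP content, with a stated time of 72 h; on this read-out higher numbers stand for an effect only at larger amounts of compound and lower numbers for an effect already at smaller amounts. In this assay compound 1 gives 16000 nM, the highest number of the three, meaning that it affects the cells only at the largest amounts. Compound 2 gives 7100 nM and compound 3 gives 5390 nM; both of these gaps to compound 1 lie beyond the usual scatter, so compound 1 is the least cytotoxic of the three on the evidence at hand.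

The next compound, compound 4, `Clc1ccc(Oc2ccc3c(NCCCNCc4ccco4)ccnc3c2)cc1`, is not yet measured. It differs from compound 1 in one place: 4-chlorophenoxy in place of isobutyl on an aromatic carbon

Within the data shown here, no pair of measured compounds differs in exactly one place, so no single step gives a direct guide. Compound 2, which also carries a phenoxy group on its core, gives 7100 nM, lower than compound 1, and this is the closest pointer available. On that basis a moderate step toward a lower number is expected for compound 4, beyond the scatter. The expected step from compound 1 to compound 4 is a 2.5-fold lower number from compound 1 to compound 4 (0.39 log units; beyond the scatter). The estimate for compound 4 in this assay is therefore 6500 nM, with a range from 2800 nM to 15000 nM.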

Compound 4, half-maximal effective concentration: 7800 nM
The estimate for compound 4 lay 1.2-fold (0.08 log units) below the measured number; measured number inside the range.
By their numbers in this assay, from the lowest: compounds 3, 2 and 4 (each within the scatter of the next); then compound 1.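

Among these compounds, the new result gives the first comparison in which only one place changes: in this assay, putting 4-chlorophenoxy in place of isobutyl on the aromatic carbon gives a 2.1-fold lower number from compound 1 to compound 4 (0.31 log units; beyond the scatter), with the rest of the molecule the same. The entering group is the larger of the two and brings a six-membered aromatic ring, an oxygen and a chlorine, yet the number moves only modestly, and this position therefore carries a much larger group with little more than a small shift toward cytotoxicity at smaller amounts. Nothing measured here points to the cause of this shift.

This single swap changes several things at once, so it cannot show whether the ring, the linking oxygen or the chlorine accounts for the step; a plain phenoxy group without the chlorine would begin to separate them. On these data alone, how the cells respond to a very different group at this position, such as a carboxylic acid or an amine, also remains open.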